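Sulfonamide nitrogen groups: from compound 2 to compound 3

The source may report more compounds than this note shows. Statements on the series, on what has been measured and on what is new or still open speak of the compounds shown alone.

Compound 1 `Cc1ccc(NS(=O)(=O)c2ccc(N3CCNC3=O)cc2)cc1`: 610 nM
Compound 2 `Cc1cccc(NS(=O)(=O)c2ccc(N3CCNC3=O)cc2)c1C`: 230 nM

In a functional assay on MCF7 cells (Homo sapiens) for antiproliferative activity, read by sulforhodamine B assay, with a stated time of 48 h (on this read-out lower numbers stand for stronger inhibition and higher numbers for weaker inhibition), compound 2 holds the lower of the two numbers, at 230 nM, and compound 1 stands at 610 nM. The next compound, compound 3 `O=C1NCCN1c1ccc(S(=O)(=O)Nc2cccc(Cl)c2)cc1`, has 3-chlorophenyl in place of 2,3-dimethylphenyl on a sulfonamide nitrogen. Within the data shown here, one measured step bears on this change: a 2.7-fold lower number from compound 1 to compound 2 (0.42 log units; beyond the scatter), with 2,3-dimethylphenyl in place of 4-methylphenyl. That step is modest but beyond the scatter. Among the measured compounds shown here, no measured compound carries a chlorine on this group, so the guide is thin. With only a 2.7-fold lower number from compound 1 to compound 2 (0.42 log units; beyond the scatter) to go on, a step of similar modest size towards a higher number is expected in this assay. The expected change is a 1.7-fold higher number from compound 2 to compound 3 (0.24 log units; within the scatter). Compound 3 is estimated at 400 nM, with an expected range from 130 nM to 1200 nM.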

Compound 3, half-maximal inhibitory concentration: 79 nM
Compound 3: the middle estimate sits 5.1-fold (0.70 log units) above what was measured, and the stated range ends above it.
By their numbers in this assay, from the lowest: compound 3; then compound 2; then compound 1.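

In this assay, 3-chlorophenyl on the sulfonamide nitrogen goes past both methyl-bearing groups: the change from 2,3-dimethylphenyl gives a 2.9-fold lower number from compound 2 to compound 3 (0.46 log units; beyond the scatter), and the change from 4-methylphenyl gives a 7.7-fold lower number from compound 1 to compound 3 (0.89 log units; beyond the scatter). Among these compounds, compounds 1 and 2 showed only that the number moves with the methyl groups on this phenyl; compound 3 shows that a chlorine-bearing phenyl with no methyl group reaches a lower number than either, so methyl is not required here for the lowest number so far. Nothing measured on these compounds accounts for the drop.

On these data alone, whether the gain belongs to chlorine itself stays open, and 3-methylphenyl or 3-fluorophenyl would test that directly. As far as these compounds go, it is also open how this position responds to a nitrile, a methoxy group or a carboxylic acid on the phenyl, or to a saturated cyclohexyl group in its place.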